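This account rests on a few compounds, and the source may have more. Where it says the series, first, only, none or still open, it means among the compounds named here.

The account begins with three measured compounds sharing one core. Compound 1 `O=C(O)Cc1sc(Cc2ccccc2-c2ccccc2)nc1-c1ccc(Cl)cc1`, compound 2 `O=C(O)Cc1sc(C(c2ccc(F)cc2)c2ccc(F)cc2)nc1-c1ccnc(N2CCCC2)c1` and compound 3 `O=C(O)Cc1sc(CSc2ccccc2)nc1-c1ccc(Cl)cc1` were all examined in an in vitro functional assay on HEK285-7 cells for antagonist activity at prostaglandin D2 receptor 2 (Homo sapiens), read by BRET and beta-arrestin recruitment; a higher number here means a larger maximal response, a lower number a smaller maximal response. In this assay compound 1 reaches 50%, compound 3 reaches 50%, and compound 2 reaches 80%. Compound 2 therefore stands highest of the three, and its distance from both compound 1 and compound 3 lies beyond the scatter of the measurement. Compound 1 and compound 3 give numbers that sit within the scatter of each other.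

Compound 4 `O=C(O)Cc1sc(C(c2ccc(F)cc2)c2ccc(F)cc2)nc1-c1ccnc(F)c1` has not yet been measured. It departs from compound 2 in a single place: fluoro in place of pyrrolidin-1-yl on an aromatic carbon. Put one bond further out, the group 2-(pyrrolidin-1-yl)pyridin-4-yl becomes 2-fluoropyridin-4-yl, next to the ring nitrogen and meta to a large group.

Going by the values given here, no pair of measured compounds differs in only one place, so there is no measured step to lean on. The expectation is that the step from compound 2 to compound 4 in this assay, a number 15 percentage points lower from compound 2 to compound 4 (beyond the scatter), is a moderate decrease, since compound 1, which lacks the pyrrolidin-1-yl group, gives the lower number 50% and compound 3, which also lacks it, gives the lower number 50%. Compound 4 is thus estimated to give 65%, within a range from 40% to 90%.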

Compound 4, largest response reached (reported as efficacy), in percent of the reference or control that the assay uses: 80%
Estimate against measurement, compound 4: 15 percentage points below, within the range that was stated.
By their numbers in this assay, from the lowest: compounds 1 and 3 (each within the scatter of the next); then compounds 2 and 4 (each within the scatter of the next).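

In this assay, replacing pyrrolidin-1-yl with fluoro on this aromatic carbon, next to the ring nitrogen, gives no change at the digits printed from compound 2 to compound 4 (within the scatter). Going by these compounds alone, this is the first comparison here in which only one place differs, and it shows that a group of 5 heavy atoms, with its non-aromatic ring and hydrogen-bond acceptor, can give way to a single fluorine atom without a readable change in the largest response reached. Nothing in the data accounts for this outcome.

From the compounds shown here alone, whether the response would also hold with a methoxy group, a morpholin-4-yl group or a plain hydrogen at this position remains open. Going by these compounds, it is also open whether fluoro and pyrrolidin-1-yl would again match if the rest of the molecule were different.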